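Nitro to methoxy: from compound 2 to compound 3

A few compounds are considered here, and "the series" means these few. Any claim that something is new, unique, unknown or untested is made for them only; others in the source may bear on it.

Compound 2 `Cn1c(-c2ccc([N+](=O)[O-])cc2)cnc1NC(=O)c1ccc(F)cc1` is the reference point for this step. In a toxicity assay on THP-1 cells (Homo sapiens) for inhibition (a higher number here means that more compound is tolerated, a lower number that less compound is tolerated), compound 2 gives > 50000 nM, which is a limit of the assay and not a number. Among the measured compounds shown here, compound 1 `COc1ccc(-c2cnc(NC(=O)C3CCNCC3)n2C)cc1` is the only other measured compound. In this assay compound 1 gives > 100000 nM, which is also a limit.

Compound 3 `COc1ccc(-c2cnc(NC(=O)c3ccc(F)cc3)n2C)cc1` differs from compound 2 by methoxy in place of nitro on an aromatic carbon, para to a large group (methoxy in place of nitro on an aromatic carbon). For the measured compounds named here, no measured step between two compounds is available to size this change. The methoxy group of compound 3 also occurs in compound 1, whose value of > 100000 nM is a limit. With that limit for compound 1, no step beyond the usual scatter is expected in this assay. The expected change is a step that the limit leaves unreadable from compound 2 to compound 3. A limit rather than a number is the most likely report for the new measurement. For compound 3 the estimated half-maximal cytotoxic concentration is 60000 nM, with an expected range of 25000 nM to 100000 nM.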

Compound 3, half-maximal cytotoxic concentration: >= 50000 nM
Compound 3: only a limit was reported; the forecaster's own chance of this, stated with the estimate: 75%; the middle value lies beyond the limit too.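

In this assay the values of compound 1, compound 2 and compound 3 are all limits, so neither the step from compound 2 to compound 3 nor the step from compound 1 to compound 3 can be read. The compounds shown leave open whether methoxy in place of nitro, or 4-fluorophenyl in place of piperidin-4-yl, changes the tolerated concentration at all.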